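The compounds below may be only part of what the source reports. "The series", "measured", "known", "first", "only" and "open" are said of these compounds alone.

Of the compounds shown here, two have been measured in a functional assay for inhibition, with a stated time of 2 h, tested at 0.0625 g/L; on this read-out higher numbers stand for more inhibition at the one concentration tested (going by the name of the read-out) and lower numbers for less inhibition. Compound 1 `Cc1sc2c(Nc3ccc(C#N)cc3)cccc2c1C` gives 69% in this assay, and compound 2 `Cc1sc2c(Nc3cccnc3)cccc2c1C` gives 70.9%. Compound 2 holds the higher of the two numbers, but its gap to compound 1 lies within the usual scatter of such measurements, so the two cannot be told apart on this read-out. Compound 3 `Cc1sc2c(Nc3ccccn3)cccc2c1C` has not been measured yet. It differs from compound 2 in one place: pyridin-2-yl in place of pyridin-3-yl on a nitrogen on an aromatic ring. For the measured compounds named here, no measured pair shows what such a change does here, so there is no basis for expecting a step beyond the scatter in either direction in this assay. The expected step is therefore small, a number 5.9 percentage points lower from compound 2 to compound 3 (within the scatter). Compound 3 is estimated to give 65% in this assay, within a range from 45% to 85%.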

Compound 3, a percentage reported as inhibition, at one concentration (the size of the read-out at that concentration, not a potency): 45.8%
Beside the measured number, compound 3's estimate is 19.2 percentage points above it, within the range that was stated.
By their numbers in this assay, from the lowest: compound 3; then compounds 1 and 2 (each within the scatter of the next).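

The earlier compounds shown here offered no measured pair at this place, and one now exists: in this assay, pyridin-2-yl in place of pyridin-3-yl on a nitrogen on an aromatic ring gives a number 25.1 percentage points lower from compound 2 to compound 3 (beyond the scatter) on an otherwise unchanged structure. The two groups have the same atoms and the same counts of hydrogen-bond donors and acceptors, yet the different joining alone is enough to shift the number beyond the scatter. Nothing at hand explains why this change lowers the number.

Still open, going by these compounds, is how a pyridin-4-yl group on the same nitrogen would compare with these two pyridine groups. On these data alone, it is also open whether a phenyl ring carrying an amine or a carboxylic acid would keep the number near that of compound 2.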